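Replacing (3-aminophenyl)amino with piperazin-1-yl on a shared core

A few compounds are considered here, and "the series" means these few. Any claim that something is new, unique, unknown or untested is made for them only; others in the source may bear on it.

Compound 1 (`Nc1cccc(Nc2c(C(=O)NCc3ccc(F)cc3)nc(Br)c3cccnc23)c1`) is the starting point, tested in a functional assay on SK-BR-3 cells (Homo sapiens) for cytotoxicity, read by MTT assay, with a stated time of 72 h; on this read-out higher numbers stand for weaker inhibition and lower numbers for stronger inhibition. In this test compound 1 reads > 10000 nM, which is a limit of the assay and not a number. Its position is therefore (the limit of > 10000 nM in this assay, at which 1 of the 2 values shown sits). A second molecule, compound 2 (`N[C@H]1CC[C@H](Nc2c(C(=O)NCc3ccc(Cl)cc3)nc(Br)c3cccnc23)CC1`), gives a true number: compound 2 reads 2000 nM.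

Compound 3 (`O=C(NCc1ccc(F)cc1)c1nc(Br)c2cccnc2c1N1CCNCC1`) keeps the core of compound 1 and changes one place, an aromatic carbon para to the bromo group, where piperazin-1-yl stands in place of (3-aminophenyl)amino: piperazin-1-yl in place of (3-aminophenyl)amino on an aromatic carbon. For the measured compounds named here, no measured pair shows this change directly. Going by the values given here, the only number to lean on is that of compound 2 at 2000 nM, so a moderate move towards stronger inhibition in this assay is expected. The expected size is an at least 2.5-fold lower number from compound 1 to compound 3 (0.39 log units; beyond the scatter). For compound 3 the estimate is 4000 nM, with an expected range from 1300 nM to 12000 nM.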

Compound 3, half-maximal inhibitory concentration: 6000 nM
Estimate against measurement, compound 3: 1.5-fold (0.18 log units) below; the measured number falls inside the stated range.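

At this aromatic carbon, para to the bromo group, a non-aromatic ring in the form of piperazin-1-yl gives compound 3 a true number in this assay, which places this position on the readable part of the scale. The pair shows an at least 1.6-fold lower number from compound 1 to compound 3 (0.22 log units; that floor lies within the scatter), so the real gap may be larger, but the part that is secured does not clear the usual scatter. The step stays a floor because the value for compound 1 is a limit of the assay and not a number: the limit of > 10000 nM in this assay, at which 1 of the 3 values shown sits.

Open, as far as these compounds go, is whether the second ring nitrogen of piperazin-1-yl matters at this place, which morpholin-4-yl, with an oxygen atom in its stead, would test. Compound 2 differs from compound 3 in more than one place, so it cannot settle this.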